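A few compounds are considered here, and "the series" means these few. Any claim that something is new, unique, unknown or untested is made for them only; others in the source may bear on it.

Measured so far:
compound 1 `O=C1O[C@@H](CN2CCC(c3ccc(F)cc3)CC2)CN1c1ccc(-n2cc(-c3ccccn3)cn2)c(F)c1` — <= 19400 nM
compound 2 `O=C1O[C@@H](Cn2ccnc2)CN1c1ccc(-n2cc(-c3ccccn3)cn2)c(F)c1` — 12300 nM

Compound 1 `O=C1O[C@@H](CN2CCC(c3ccc(F)cc3)CC2)CN1c1ccc(-n2cc(-c3ccccn3)cn2)c(F)c1` returns only a limit of the assay in a physicochemical assay for solubility, read by HPLC, with a stated time of 24 h (a lower number here means a less soluble compound, a higher number a more soluble compound), namely <= 19400 nM. For the measured compounds named here, compound 2 `O=C1O[C@@H](Cn2ccnc2)CN1c1ccc(-n2cc(-c3ccccn3)cn2)c(F)c1` is the only compound with a number in this assay, giving 12300 nM. The other value shown, that of compound 1, is a limit (the limit of <= 19400 nM in this assay, at which 1 of the 2 values shown sits). Going by the values given here, no step between measured compounds is available, so the pair tells nothing about how any change moves solubility.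

Compound 3 `CNC(=O)[C@H]1CN(c2ccc(-n3cc(-c4ccccn4)cn3)c(F)c2)C(=O)O1` differs from compound 2 in one place: methylcarbamoyl in place of (1H-imidazol-1-yl)methyl on a saturated ring carbon. Methylcarbamoyl is a smaller group than the (1H-imidazol-1-yl)methyl it replaces, and no measured step shows the effect of such an exchange. The step from compound 2 to compound 3 is therefore expected to be modest, at most slightly upward and within or near the scatter, a 1.2-fold higher number from compound 2 to compound 3 (0.09 log units; within the scatter). Compound 3 is estimated at 15000 nM, with a range from 5000 nM to 45000 nM.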

Compound 3, solubility: 26200 nM
Compound 3: middle estimate off by 1.7-fold (0.24 log units), on the low side; the measured number falls inside the stated range.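

In this assay the saturated ring carbon next to the ring oxygen now has a readable step, with methylcarbamoyl in place of (1H-imidazol-1-yl)methyl giving a 2.1-fold higher number from compound 2 to compound 3 (0.33 log units; beyond the scatter), so the read-out responds to a change at this position. The exchange removes a five-membered aromatic ring and brings in a hydrogen-bond donor and a double bond outside aromatic rings, and this single pair cannot separate those differences. Nothing measured here bears on why the number moves.

Compound 1 gives only a limit, <= 19400 nM, and steps involving it cannot be read. As far as these compounds go, whether a carboxylic acid, a primary amine or a longer chain on this carbon would carry the number further in the same direction remains open.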